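Swapping methoxy for nitro in a weakly cytotoxic series

A few compounds are considered here, and "the series" means these few. Any claim that something is new, unique, unknown or untested is made for them only; others in the source may bear on it.

Compound 1 `COc1cc(-c2nnc3n2NC(c2ccco2)C(C(=O)c2ccccc2F)S3)cc(OC)c1OC`: 94800 nM
Compound 2 `COc1ccc(C(=O)C2Sc3nnc(-c4cc(OC)c(OC)c(OC)c4)n3NC2c2ccco2)cc1`: > 100000 nM

In a functional assay on MCF7 cells (Homo sapiens) for cytotoxicity, read by MTT assay, with a stated time of 48 h (a higher number here means a weaker inhibitor, a lower number a stronger inhibitor), compound 1 gives 94800 nM. For compound 2 the assay reports only a limit, > 100000 nM. For the measured compounds named here, the one measured step, an at least 1.0-fold higher number from compound 1 to compound 2 (0.02 log units; that floor lies within the scatter), lies within the scatter, and the limit of > 100000 nM in this assay, at which 1 of the 2 values shown sits, caps what it can show. Compound 3 `COc1cc(-c2nnc3n2NC(c2ccco2)C(C(=O)c2ccc([N+](=O)[O-])cc2)S3)cc(OC)c1OC` differs from compound 2 by nitro in place of methoxy on an aromatic carbon. Going by the values given here, no measured step exchanges these two groups, so guidance is thin, and compound 2 already sits at a limit. Compound 3 is expected near 100000 nM, between 40000 nM and 250000 nM. The expected step of a number no higher from compound 2 to compound 3 (the limit leaves the size open) stays within the scatter.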

Compound 3, half-maximal inhibitory concentration: > 100000 nM
Compound 3: only a limit was reported; the forecaster's own chance of this, stated with the estimate: 60%; the middle value sits exactly at the limit.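

Compound 3, like compound 2, reaches only a limit in this assay, so a nitro group on this ring brings no measurable cytotoxicity, just as methoxy brought none. Against the 2-fluorophenyl ketone, the change gives an at least 1.0-fold higher number from compound 1 to compound 3 (0.02 log units; that floor lies within the scatter). The exchange of methoxy for nitro itself cannot be read because both values are limits: the limit of > 100000 nM in this assay, at which 2 of the 3 values shown sit.

From the compounds shown here alone, whether an amine or a carboxylic acid at this place on the ring would give a number clearly under the limit stays open. So does whether any real difference between compound 2 and compound 3 lies hidden beyond it.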